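Cyclohexyloxy in place of dimethylpiperidinyl: compound 4

The compounds below may be only part of what the source reports. "The series", "measured", "known", "first", "only" and "open" are said of these compounds alone.

Measured in an assay on CHO cells for antagonist activity at transient receptor potential cation channel subfamily V member 1 (Homo sapiens), read by FLIPR; on this read-out lower numbers stand for stronger inhibition and higher numbers for weaker inhibition:
compound 1 `CC(C(=O)NCc1ccc(C(F)(F)F)cc1N1CCC(C)(C)CC1)c1ccc(NS(C)(=O)=O)c(F)c1`: 1.3 nM
compound 2 `Cc1ccc(N2CCN(c3cc(C(F)(F)F)ccc3CNC(=O)C(C)c3ccc(NS(C)(=O)=O)c(F)c3)CC2)cc1`: 0.7 nM
compound 3 `CCCCCCOc1cc(C(C)(F)F)ccc1CNC(=O)C(C)c1ccc(NS(C)(=O)=O)c(F)c1`: 0.8 nM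

Compound 1 carries the highest of the three numbers, yet its gaps to compound 3 and to compound 2 both lie within the scatter of repeat measurements, so no order can be read among the three. Compound 4 `CC(C(=O)NCc1ccc(C(F)(F)F)cc1OC1CCCCC1)c1ccc(NS(C)(=O)=O)c(F)c1` is drawn from compound 1 by a single change: cyclohexyloxy in place of 4,4-dimethylpiperidin-1-yl on an aromatic carbon. Among the compounds with values here, no measured pair isolates this change. Compound 3 also carries an alkoxy group rather than the piperidinyl and gives 0.8 nM in this assay, so the expected step from compound 1 to compound 4 is a 1.2-fold higher number from compound 1 to compound 4 (0.06 log units; within the scatter), with no clear direction and nothing beyond the scatter. Compound 4 is estimated at 1.5 nM in this assay, with a range of 0.5 nM to 5 nM.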

Compound 4, inhibition constant: 0.7 nM
Compound 4: middle estimate off by 2.1-fold (0.33 log units), on the high side, within the range that was stated.
By their numbers in this assay, from the lowest: compounds 2, 4, 3 and 1 (each within the scatter of the next).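

In this assay, within the data shown here, cyclohexyloxy in place of 4,4-dimethylpiperidin-1-yl gives a 1.9-fold lower number from compound 1 to compound 4 (0.27 log units; within the scatter) on this aromatic carbon, the first step that isolates a change at this position. The step stays within the scatter, so the position accepts an oxygen-linked carbon ring as well as the nitrogen-linked dimethylpiperidine ring, with no readable difference between them. Nothing available explains why the two groups read alike.

Still open, going by these compounds, is whether a much smaller group such as methoxy holds the value here. On these data alone, an amine with a free hydrogen, such as cyclohexylamino, or a carboxylic acid at this position is equally open.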